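Swapping methoxy for chloro on the aryl ring of compound 3

The source may hold more compounds than are shown below. What is called first, only, known or untested is meant among the compounds shown, and "the series" means these compounds.

Measured compounds:
compound 1, `CC(c1ccc(-c2ccccc2)c(F)c1)c1nnc2n1N=C(c1ccc(Cl)cc1Cl)CS2`, 6900 nM
compound 2, `CC(c1ccc(-c2ccccc2)c(F)c1)c1nnc2n1N=C(c1ccccc1)CS2`, 9700 nM
compound 3, `COc1ccc(C2=Nn3c(nnc3C(C)c3ccc(-c4ccccc4)c(F)c3)SC2)cc1`, 4400 nM

These three share one core and differ only in the aryl group on a carbon with a double bond to nitrogen. In a functional assay on HCT-116 cells (Homo sapiens) for inhibition, read by sulforhodamine B assay, with a stated time of 72 h (on this read-out higher numbers stand for weaker inhibition and lower numbers for stronger inhibition), compound 3 gives the lowest of the three numbers. Its gap to compound 1 is small, a 1.6-fold lower number from compound 1 to compound 3 (0.20 log units; within the scatter), so those two cannot be told apart, whereas a 2.2-fold lower number from compound 2 to compound 3 (0.34 log units; beyond the scatter) is a modest but real step.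

Compound 4, `CC(c1ccc(-c2ccccc2)c(F)c1)c1nnc2n1N=C(c1ccc(Cl)cc1)CS2`, has not yet been measured. It differs from compound 3 by chloro in place of methoxy on an aromatic carbon.

For the measured compounds named here, no measured step tests chloro against methoxy directly. Going by the values given here, the only step touching that position is a 2.2-fold lower number from compound 2 to compound 3 (0.34 log units; beyond the scatter), where adding methoxy in place of hydrogen helped modestly. The steps of a 1.4-fold higher number from compound 1 to compound 2 (0.15 log units; within the scatter) and a 1.6-fold lower number from compound 1 to compound 3 (0.20 log units; within the scatter) show that a chlorinated aryl group, here compound 1 with two chlorines, sits between the plain phenyl of compound 2 and the methoxy of compound 3. A single chloro is therefore expected to give a number near that of compound 3, perhaps a little higher, with a step of a 1.4-fold higher number from compound 3 to compound 4 (0.13 log units; within the scatter) that stays within the scatter. Compound 4 is estimated at 6000 nM, between 3000 nM and 12000 nM.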

Compound 4, half-maximal inhibitory concentration: 7800 nM
Compound 4: middle estimate off by 1.3-fold (0.11 log units), on the low side; the range from low to high includes it.
By their numbers in this assay, from the lowest: compounds 3, 1, 4 and 2 (each within the scatter of the next, the first and the last beyond it).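

In this assay, chloro in place of methoxy gives a 1.8-fold higher number from compound 3 to compound 4 (0.25 log units; within the scatter) and chloro in place of hydrogen gives a 1.2-fold lower number from compound 2 to compound 4 (0.09 log units; within the scatter), so compound 4 cannot be told apart from either of its neighbours, even though those two neighbours are separated by a 2.2-fold lower number from compound 2 to compound 3 (0.34 log units; beyond the scatter). Taking one chloro away from the dichlorinated aryl group gives a 1.1-fold higher number from compound 1 to compound 4 (0.05 log units; within the scatter), so having one chloro rather than two makes no readable difference on this aryl group. For the compounds shown here, of the single changes now seen on this aryl group, methoxy in place of hydrogen is still the only one that goes beyond the scatter, and it is a modest step, so chloro adds no second clear change at this position.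

Nothing available here explains why these numbers fall as they do. From the compounds shown here alone, it remains open what a group of another kind would do at this place, such as an amine, a carboxylic acid or a longer chain like butoxy, and whether any of them would move the number well beyond the narrow band that these four compounds occupy.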